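A few compounds are considered here, and "the series" means these few. Any claim that something is new, unique, unknown or untested is made for them only; others in the source may bear on it.

Compound 1 `Cc1ccccc1Nc1nc(NC2CC2)ncc1Cl` gives only a limit in a functional assay on Jurkat cells (Homo sapiens) for inhibition, read by CCK-8 assay, with a stated time of 48 h (a lower number here means a stronger inhibitor of growth, a higher number a weaker inhibitor of growth), namely > 100000 nM.
Compound 2 `Cc1ccccc1Nc1nc(Nc2ccc(N3CCN(C)CC3)cc2)ncc1Cl` gives 13700 nM.
Compound 3 `CN1CCN(c2ccc(Nc3ncc(Cl)c(Nc4ccccc4)n3)nc2)CC1` gives only a limit, > 100000 nM.

Compound 3 therefore stands at the limit of > 100000 nM in this assay, at which 2 of the 3 values shown sit, where it shares that limit with compound 1, and no number is known for it. Compound 4 `CC(C)c1cccc(Nc2nc(Nc3ccc(N4CCN(C)CC4)cn3)ncc2Cl)c1` differs from compound 3 in one change: isopropyl in place of hydrogen on an aromatic carbon, placed on an aromatic carbon of a six-membered aromatic ring of carbon only, meta to a large group. Within the data shown here, no measured pair here differs in a single place, so no measured step serves as a guide. In this assay the step from compound 3 to compound 4 is expected to be small and toward stronger inhibition at most, about an at least 1.6-fold lower number from compound 3 to compound 4 (0.22 log units; that floor lies within the scatter). Compound 4 is estimated at 60000 nM, between 15000 nM and 200000 nM.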

Compound 4, concentration for 50% growth inhibition: 12300 nM
Estimate against measurement, compound 4: 4.9-fold (0.69 log units) above, and the stated range ends above it.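

Changing phenyl to 3-isopropylphenyl gives an at least 8.1-fold lower number from compound 3 to compound 4 (0.91 log units; beyond the scatter) in this assay. Among these compounds, this is the only measured pair here that differs in one place, and it shows that growth inhibition responds to a change at this position. The true size of the step stays unknown, because compound 3 gives only a limit: the limit of > 100000 nM in this assay, at which 2 of the 4 values shown sit.

From the compounds shown here alone, it remains open whether isopropyl itself matters, or whether an amine, a carboxylic acid or a longer chain at this place would do the same. Going by these compounds, it is also open whether isopropyl elsewhere on this ring would give a similar step.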